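The source may report more compounds than this note shows. Statements on the series, on what has been measured and on what is new or still open speak of the compounds shown alone.

Measured so far in a functional assay on QGY cells (Homo sapiens) for cytotoxicity, read by MTT assay, with a stated time of 48 h; a higher number here means a weaker inhibitor, a lower number a stronger inhibitor:

compound 1 `COc1cc([C@H]2C[C@]2(CO)C(=O)Nc2ccccc2Cl)cc(OC)c1OC` gives 40700 nM
compound 2 `CCOC(=O)C1(C(=O)Nc2ccc(F)cc2)CC1c1cc(OC)c(OC)c(OC)c1` gives 79100 nM; 36100 nM (2 entries)
compound 3 `CCOC(=O)[C@]1(C(=O)Nc2ccccc2Cl)C[C@@H]1c1cc(OC)c(OC)c(OC)c1` gives 34700 nM

Among the measured compounds shown here, on these numbers compound 3 stands level with compound 1: the only single-place step recorded, a 1.2-fold lower number from compound 1 to compound 3 (0.07 log units; within the scatter), lies within the scatter, so no order between the two can be claimed. Compound 2 carries no drawn configuration, and its repeated entries the several entries of compound 2 in this assay, 79100 nM; 36100 nM (2 entries) show how far one compound's number can wander in this assay.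

Compound 4 `CCOC(=O)[C@@]1(C(=O)Nc2ccccc2Cl)C[C@H]1c1cc(OC)c(OC)c(OC)c1` is the next case. (the two compounds have the same atoms and bonds and differ only in configuration as drawn: 2 of 2 stereo elements differ (all stereocentres are inverted: mirror images); a stereocentre at a saturated ring carbon is drawn R in compound 3 and S in compound 4; a stereocentre at a saturated ring carbon is drawn R in compound 3 and S in compound 4). For the measured compounds named here, none of the measured steps concerns a change of configuration alone; the step of a 1.2-fold lower number from compound 1 to compound 3 (0.07 log units; within the scatter) exchanges a group and offers no guide for mirror images. The spread of compound 2 seen in the several entries of compound 2 in this assay, 79100 nM; 36100 nM (2 entries) suggests that a difference in configuration could pass unnoticed or could matter considerably. Without directional evidence, compound 4 is expected to land near compound 3, with a deliberately wide range. The estimate for compound 4 is 50000 nM, expected to fall between 20000 nM and 150000 nM. The expected step is a 1.4-fold higher number from compound 3 to compound 4 (0.16 log units; within the scatter), essentially no change beyond the scatter.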

Compound 4, half-maximal inhibitory concentration: 34300 nM
For compound 4 the middle estimate is 1.5-fold (0.16 log units) above the measured one; low and high end bracket the measured number.
By their numbers in this assay, from the lowest: compounds 4, 3 and 1 (each within the scatter of the next).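

Inverting both stereocentres on the saturated ring in this assay gives a 1.0-fold lower number from compound 3 to compound 4 (0.01 log units; within the scatter) and so leaves no readable difference between these two mirror images. Among the compounds shown here, this is the first comparison that tests configuration with every group held in place, as the change from hydroxymethyl to ethoxycarbonyl could not: the fact that compounds 3 and 4 differ only in the configuration as drawn. A gap this small also sits well inside the distance that repeated entries for a single compound can wander: the several entries of compound 2 in this assay, 79100 nM; 36100 nM (2 entries).

From the compounds shown here alone, whether the two configurations would also stay level with hydroxymethyl remains open, as that group appears only in compound 1, in a single drawn configuration. Also open, going by these compounds, is how the number would respond to a carboxylic acid or a primary amine in place of ethoxycarbonyl on the saturated ring carbon.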